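Ester to Acid on a Triazole Amide at the Limit

The source may hold more compounds than are shown below. What is called first, only, known or untested is meant among the compounds shown, and "the series" means these compounds.

Compound 1 `COC(=O)c1ccc(-c2cn(CC(=O)Nc3nc(C)cs3)nn2)cc1` is one of three amides that share a core and differ only in the group on the amide-type nitrogen. In a functional assay on BMDM cells (Mus musculus, strain C57BL/6) for inhibition, with a stated time of 2 days (on this read-out lower numbers stand for stronger inhibition and higher numbers for weaker inhibition), compound 1 gives > 30000 nM, which is a limit of the assay and not a number. Compound 2 `COC(=O)c1ccc(-c2cn(CC(=O)Nc3nc4ccccc4s3)nn2)cc1` gives > 30000 nM, again a limit. Compound 3 `COC(=O)c1ccc(-c2cn(CC(=O)Nc3cc(C)on3)nn2)cc1` gives > 30000 nM, also a limit. Because all three sit at the limit of > 30000 nM in this assay, at which 3 of the 3 values shown sit, the steps a step that the two limits leave unreadable from compound 1 to compound 2, a step that the two limits leave unreadable from compound 1 to compound 3 and a step that the two limits leave unreadable from compound 2 to compound 3 cannot be read, and none of them touches the ester. Compound 4 `Cc1csc(NC(=O)Cn2cc(-c3ccc(C(=O)O)cc3)nn2)n1` differs from compound 1 by hydrogen in place of methyl on an oxygen next to a carbonyl group. Among the compounds with values here, no measured step bears on this change. The expected step is a number no higher from compound 1 to compound 4 (the limit leaves the size open). Compound 4 is therefore estimated at 30000 nM, with a range from 5000 nM to 100000 nM.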

Compound 4, half-maximal inhibitory concentration: > 30000 nM
Compound 4: a limit, no number (the forecaster's own chance of this, stated with the estimate: 85%); the middle value lies on the limit itself.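

Compound 4 gives > 30000 nM in this assay, which is a limit and not a number, so no new step can be read from compound 1 to compound 4. The compounds shown leave open whether methoxycarbonyl or carboxy, or any amide group, changes inhibition at all.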